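A few compounds are considered here, and "the series" means these few. Any claim that something is new, unique, unknown or untested is made for them only; others in the source may bear on it.

Measured compounds:
- compound 1, `C#CCNC1CCc2c(SCCc3cccc(Cl)c3)cccc21` — in an ADME assay on isolated protein for inhibition of Amine oxidase [flavin-containing] B (Homo sapiens) (a lower number here means a stronger inhibitor, a higher number a weaker inhibitor), compound 1 gives "not determined" (no result reported)
- compound 2, `C#CCNC1CCc2c(SCCc3cccc(OC)c3)cccc21` — in this assay compound 2 gives 3820 nM
- compound 3, `C#CCNC1CCc2c(SCCc3ccc(OC)cc3)cccc21` — in this assay compound 3 gives 4590 nM

Compound 3 carries the highest of the two numbers available, though its nearest neighbour compound 2 differs only by a 1.2-fold higher number from compound 2 to compound 3 (0.08 log units; within the scatter), so the two are not separated on this assay. Compound 1 contributes no number and cannot anchor anything.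

The next compound, compound 4, `C#CCNC1CCc2c(SCCc3cccc(F)c3)cccc21`, differs from compound 3 by 3-fluorophenyl in place of 4-methoxyphenyl on a saturated chain carbon, two bonds along the chain from a sulfur.

Among the compounds with values here, the only measured step, a 1.2-fold higher number from compound 2 to compound 3 (0.08 log units; within the scatter), moves a methoxy group around the ring and stays within the scatter. Within the data shown here, no measured step exchanges a methoxy group for a halogen, and compound 1, the nearest halogen-bearing analogue, has no number. The expectation therefore rests on the series showing little movement so far: compound 4 is estimated to sit close to compound 3, with the step of a 1.1-fold lower number from compound 3 to compound 4 (0.06 log units; within the scatter) expected to lie within the scatter. Compound 4 is estimated at 4000 nM, with a range from 1500 nM to 10000 nM.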

Compound 4, half-maximal inhibitory concentration: 7810 nM
Compound 4: middle estimate off by 2.0-fold (0.29 log units), on the low side; low and high end bracket the measured number.
By their numbers in this assay, from the lowest: compounds 2, 3 and 4 (each within the scatter of the next, the first and the last beyond it).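

In this assay, the exchange of 4-methoxyphenyl for 3-fluorophenyl gives a 1.7-fold higher number from compound 3 to compound 4 (0.23 log units; within the scatter) and stays within the scatter, so this change alone does not separate the pair. Within the data shown here, the cleaner comparison, fluoro in place of methoxy on an aromatic carbon, gives a 2.0-fold higher number from compound 2 to compound 4 (0.31 log units; beyond the scatter) and is the first step beyond the scatter: modest in size, with the fluoro compound the weaker inhibitor of that pair. Nothing on hand explains either step.

On these data alone, whether this small loss extends to other replacements for methoxy, such as trifluoromethyl or a nitrile, stays open, as does the effect of 4-fluorophenyl in place of 3-fluorophenyl. The chloro analogue, compound 1, gives no number, and a longer chain to the sulfur remains untested within the compounds shown here.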